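Methyl for chloro on a benzoxazole piperazine core

The source may hold more compounds than are shown below. What is called first, only, known or untested is meant among the compounds shown, and "the series" means these compounds.

Measured compounds:
compound 1 `Cc1cc(Cl)c2oc(N3CCN(C)CC3)nc2c1` — 6.22
compound 2 `CCc1cc(C)cc2nc(N3CCN(C)CC3)oc12` — 6.46
compound 3 `COc1cc(Cl)cc2nc(N3CCN(C)CC3)oc12` — 6.16

In a functional assay on ileum (strain Hartley) for agonist activity at 5-hydroxytryptamine receptor 3A (Cavia porcellus) (a lower number here means a less potent compound, a higher number a more potent compound, by a factor of ten per unit of this negative logarithm), compound 3 gives 6.16 and stands at the lower end of the three numbers, though its gap to compound 1 is within the scatter and its gap to compound 2 is also within the scatter, so no order among them can be read.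

Compound 4 `COc1cc(C)cc2nc(N3CCN(C)CC3)oc12` is not yet measured. It differs from compound 3 in one place: methyl in place of chloro on an aromatic carbon. Within the data shown here, the one measured step that bears on an exchange of chloro for an alkyl group is a number 0.24 log units higher from compound 1 to compound 2 (within the scatter), a change within the scatter, though at a different position of the shared core. Nothing beyond this is known about the spot where compound 4 carries its methyl.

On this basis compound 4 is expected to stay close to compound 3, with a step of a number 0.09 log units higher from compound 3 to compound 4 (within the scatter) that is estimated to lie within the scatter. The estimate for compound 4 in this assay is 6.25, with a range from 5.75 to 6.75.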

Compound 4, negative logarithm of the half-maximal effective concentration: 6.13
Compound 4: the middle estimate sits 0.12 log units above what was measured, within the range that was stated.
By their numbers in this assay, from the lowest: compounds 4, 3, 1 and 2 (each within the scatter of the next, the first and the last beyond it).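

In this assay, methyl in place of chloro on the aromatic carbon meta to a methoxy group gives a number 0.03 log units lower from compound 3 to compound 4 (within the scatter), so the two groups cannot be told apart at this position. Methoxy in place of chloro gives a number 0.09 log units lower from compound 1 to compound 4 (within the scatter), which also cannot be read as a change, while methoxy in place of ethyl gives a number 0.33 log units lower from compound 2 to compound 4 (beyond the scatter), a modest step and the only one of the three beyond the scatter. Ethyl is therefore separated from methoxy in this set, but the earlier step of a number 0.24 log units higher from compound 1 to compound 2 (within the scatter) does not separate it from chloro.

No measurement given here offers an explanation for any of these steps. From the compounds shown here alone, whether an amine, a carboxylic acid or a longer chain on this aromatic carbon would move the number remains open.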